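This account rests on a few compounds, and the source may have more. Where it says the series, first, only, none or still open, it means among the compounds named here.

Working notes on the chloroindole arylthioether series.

The shared core is carried by compound 2 `Clc1ccc2[nH]cc(Sc3ccccc3)c2c1`, compound 1 `COc1ccccc1Sc1c[nH]c2ccc(Cl)cc12` and compound 3 `COc1cc(OC)cc(Sc2c[nH]c3ccc(Cl)cc23)c1`; the fourth member, compound 4 `COc1cc(Sc2c[nH]c3ccc(Cl)cc23)cc(OC)c1OC`, is not yet measured. In an assay on isolated protein for inhibition of Indoleamine 2,3-dioxygenase 1 (Homo sapiens), read by HPLC, with a stated time of 60 min, in the presence of a further agent that is not named here (on this read-out lower numbers stand for stronger inhibition and higher numbers for weaker inhibition), compound 1 gives 17500 nM and compound 3 gives 7000 nM. For compound 2 the read-out is a limit of this assay, not a number: compound 2 gives > 200000 nM, and the limit of > 200000 nM in this assay, at which 1 of the 3 values shown sits, marks that boundary.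

The change from compound 2 to compound 1 is methoxy in place of hydrogen on an aromatic carbon, and it brought an at least 11-fold lower number from compound 2 to compound 1 (1.05 log units; beyond the scatter). The difference between the cores of compound 2 and compound 3 is not broken down here. Compound 3 holds the lowest number of the two numbers measured in this assay, with compound 1 the nearest, and the gap between them lies beyond the scatter.

The change from compound 3 to compound 4 is methoxy in place of hydrogen on an aromatic carbon. Going by the values given here, it is the same kind of change as the one from compound 2 to compound 1, but the place differs: there the entering group was ortho to a large group, here it is ortho to two methoxy groups (2 heavy atoms each) and para to a large group. As far as these compounds go, the earlier step was large, yet it started from a limit, so its full size is unknown. With two methoxy groups already in place on compound 3, a smaller gain is expected from the third. The step expected on this basis is a 1.8-fold lower number from compound 3 to compound 4 (0.24 log units; within the scatter). Compound 4 is estimated at 4000 nM, within 1500 nM to 12000 nM.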

Compound 4, half-maximal inhibitory concentration: 40000 nM
Compound 4: the middle estimate sits 10-fold (1.00 log units) below what was measured; measured number outside the range, above it.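

In this assay, methoxy in place of hydrogen on an aromatic carbon gave a 5.7-fold higher number from compound 3 to compound 4 (0.76 log units; beyond the scatter), so the change does not carry from one core to the other as a constant step: the same change on two cores in this assay, an at least 11-fold lower number (1.05 log units; beyond the scatter) from compound 2 to compound 1 and a 5.7-fold higher number (0.76 log units; beyond the scatter) from compound 3 to compound 4, at least 65-fold (1.81 log units) apart, beyond the scatter of two such steps

This shows that the direction of the step depends on the setting within this small set, but it does not show whether the core or the place is responsible, as the two steps differ in both, and in the later one the entering group is ortho to two methoxy groups and para to a large group. Compound 2 gives > 200000 nM, which is a limit of this assay and not a number: the limit of > 200000 nM in this assay, at which 1 of the 4 values shown sits.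

The compounds shown leave open whether a single methoxy group at this place, without the two methoxy groups of compound 3, would also raise the number. Also open, as far as these compounds go, is how a hydroxyl group, an amine, a carboxylic acid or a longer chain such as ethoxy would read at this place, and so whether the rise seen for compound 4 is particular to methoxy.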